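Benzimidazole carboxamide series: three limits and one open question

The compounds below may be only part of what the source reports. "The series", "measured", "known", "first", "only" and "open" are said of these compounds alone.

Measured so far:
compound 1 `CCCn1c(NC(=O)c2cccnn2)nc2cc(C(N)=O)cc(OC)c21` — > 100000 nM
compound 2 `CCCn1c(NC(=O)c2ccnn2CC)nc2cc(C(N)=O)cc(OC)c21` — > 100000 nM
compound 3 `COc1cc(C(N)=O)cc2nc(NC(=O)c3cccnn3)n(CCCNC(=O)OCc3ccccc3)c12` — > 100000 nM

In an assay for activation of interferon regulatory factor 3 (Homo sapiens), read by a luciferase reporter, with a stated time of 20 h (a higher number here means that more compound is needed for the effect, a lower number that less compound is needed), compound 1 returns a limit, not a number: > 100000 nM. Compound 2 likewise returns only a limit in this assay, > 100000 nM. Compound 3 also sits at a limit in this assay, namely > 100000 nM. Within the data shown here, all three values sit at the same point, as noted in the limit of > 100000 nM in this assay, at which 3 of the 3 values shown sit, so no step between them can be read.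

Compound 2 differs from compound 1 by 1-ethyl-1H-pyrazol-5-yl in place of pyridazin-3-yl on a carbonyl carbon. The step that the two limits leave unreadable from compound 1 to compound 2 is therefore unreadable. Compound 3 differs from compound 1 by (benzyloxycarbonyl)amino in place of hydrogen on a saturated chain carbon, three bonds along the chain from an aromatic nitrogen, and the step that the two limits leave unreadable from compound 1 to compound 3 is unreadable for the same reason.

Compound 4 `CCn1nccc1C(=O)Nc1nc2cc(C(N)=O)cc(OC)c2n1CCCNC(=O)OCc1ccccc1` is not yet measured. It differs from compound 3 by 1-ethyl-1H-pyrazol-5-yl in place of pyridazin-3-yl on a carbonyl carbon, the same change already made from compound 1 to compound 2, at a place described in the same words. Since both measured compounds carrying that change, and both carrying the core of compound 3, stand only at the limit, the expected step from compound 3 to compound 4 is a step that the limit leaves unreadable from compound 3 to compound 4, resting on the step that the two limits leave unreadable from compound 1 to compound 2 and on the limit of compound 3, > 100000 nM. For compound 4 the estimate is 150000 nM, expected between 40000 nM and 1000000 nM, most probably reported again as a limit in this assay.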

Compound 4, half-maximal effective concentration: > 100000 nM
Compound 4 ended at the assay's limit (the forecaster's own chance of this, stated with the estimate: 85%); the middle value is on the limit's open side.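

In this assay compound 4 gives > 100000 nM as a limit, not a number. The steps to compound 4 from compound 3 and from compound 2 cannot be read, as every value shown stands at one point: the limit of > 100000 nM in this assay, at which 4 of the 4 values shown sit. The compounds shown leave open whether any change on the shared core gives a number rather than a limit in this assay for this series.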